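The compounds below may be only part of what the source reports. "The series", "measured", "known", "first", "only" and "open" are said of these compounds alone.

- compound 1 `COC1=C(C)C(=O)/C(=C(O)/C=C/c2ccc(O)cc2)C(=O)C1(C)C` gives 3 ug/mL in a functional assay on KB cells (Homo sapiens) for cytotoxicity; on this read-out lower numbers stand for an effect already at smaller amounts and higher numbers for an effect only at larger amounts of compound
- compound 2 `CCc1ccc(/C=C/C(O)=C2/C(=O)C(C)=C(OC)C(C)(C)C2=O)cc1` gives 1.9 ug/mL
- compound 3 `COC1=C(C)C(=O)/C(=C(O)/C=C/c2cc(C)cc(C)c2)C(=O)C1(C)C` gives 1.6 ug/mL

Compound 1 is not separated from the other two on these numbers. The steps of a 1.6-fold lower number from compound 1 to compound 2 (0.20 log units; within the scatter) and a 1.9-fold lower number from compound 1 to compound 3 (0.27 log units; within the scatter) both stay within the scatter, as does a 1.2-fold lower number from compound 2 to compound 3 (0.07 log units; within the scatter) in this small set.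

Compound 4 `C=Cc1ccccc1/C=C/C(O)=C1/C(=O)C(C)=C(OC)C(C)(C)C1=O` keeps the shared core and carries one change, 2-vinylphenyl in place of 4-hydroxyphenyl on a double-bonded chain carbon bound to a double-bonded chain carbon in this case. Among the measured compounds shown here, two measured steps bear on it, since each also removes the hydroxy group of compound 1 while an all-carbon substituted phenyl remains: a 1.6-fold lower number from compound 1 to compound 2 (0.20 log units; within the scatter) and a 1.9-fold lower number from compound 1 to compound 3 (0.27 log units; within the scatter) are the closest guides. For the measured compounds named here, no measured compound carries 2-vinylphenyl, so the guidance is indirect. Neither guide leaves the scatter, and no step beyond the scatter is expected in this assay here. The estimated step is a 1.6-fold lower number from compound 1 to compound 4 (0.20 log units; within the scatter) and would remain within the scatter. In this assay compound 4 is expected at 1.9 ug/mL (range 0.8 ug/mL to 4.5 ug/mL).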

Compound 4, concentration for half-maximal effect: 1.1 ug/mL
Compound 4: the middle estimate sits 1.7-fold (0.24 log units) above what was measured; the measured number falls inside the stated range.
By their numbers in this assay, from the lowest: compounds 4, 3, 2 and 1 (each within the scatter of the next, the first and the last beyond it).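

In this assay, among the compounds shown here, the replacement of 4-hydroxyphenyl by 2-vinylphenyl on a double-bonded chain carbon bound to a double-bonded chain carbon gives the first step beyond the scatter (a 2.7-fold lower number from compound 1 to compound 4 (0.44 log units; beyond the scatter)). The new group is still not separated from the other all-carbon aryl groups, since both a 1.5-fold lower number from compound 3 to compound 4 (0.16 log units; within the scatter) and a 1.7-fold lower number from compound 2 to compound 4 (0.24 log units; within the scatter) stay within the scatter, so this step sets compound 4 apart from compound 1 only. No supporting measurement is available to explain the step.

Going by these compounds, it remains open whether the step follows from losing the hydroxy group or from gaining the vinyl group, as the two changes come together in compound 4. On these data alone, how a phenyl carrying an amine, a carboxylic acid or a longer carbon chain would read at this place in this assay also remains open.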